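The source may report more compounds than this note shows. Statements on the series, on what has been measured and on what is new or still open speak of the compounds shown alone.

Compound 2, with the structure `Nc1nc2c(nc(I)n2COCCO)c(=O)[nH]1`, carries a (2-hydroxyethoxy)methyl group on the shared core and an iodo substituent on an aromatic carbon. In a functional assay on L1210 cells (Mus musculus) for inhibition (a higher number here means a weaker inhibitor, a lower number a stronger inhibitor), compound 2 gives > 1000 ug/mL, which is a limit of the assay and not a number. Compound 2 therefore stands at the limit of > 1000 ug/mL in this assay, at which 1 of the 2 values shown sits. Its closest measured neighbour is compound 1, with the structure `Nc1nc2c(nc(Br)n2COCCO)c(=O)[nH]1`, where a bromo replaces the iodo. In this assay compound 1 gives > 500 ug/mL, again a limit rather than a number. Compound 1 stands at the limit of > 500 ug/mL in this assay, at which 1 of the 2 values shown sits. The step that the two limits leave unreadable from compound 1 to compound 2 cannot be sized, since both values are limits.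

Compound 3, with the structure `CN(C)c1nc2c(=O)[nH]c(N)nc2n1COCCO`, differs from compound 2 in one place: dimethylamino in place of iodo on an aromatic carbon. Within the data shown here, no measured step speaks directly to this change, and the one step that exists is unreadable, so no direction can be taken from it. Among the measured compounds shown here, the only guide is that compound 2 and compound 1 both sit at limits. For compound 3 in this assay the estimated value is 1000 ug/mL, with a range from 200 ug/mL to 5000 ug/mL. The expected step is a number no higher from compound 2 to compound 3 (the limit leaves the size open), judged as none beyond the scatter.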

Compound 3, concentration for 50% inhibition: > 500 ug/mL
Compound 3 was reported as a limit; the forecaster's own chance of this, stated with the estimate: 75%; the middle value does not contradict the limit.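

In this assay compound 3 gives > 500 ug/mL, which is a limit and not a number. The steps linking compound 3 to compound 2 and to compound 1 therefore cannot be read. The compounds shown leave open how strongly compound 1, compound 2 and compound 3 inhibit, and whether bromo, iodo or dimethylamino on this aromatic carbon makes any difference.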